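The source may report more compounds than this note shows. Statements on the series, on what has been measured and on what is new or still open speak of the compounds shown alone.

- Compound 1 `CCN(CC)CN1C(=O)/C(=N/NC(N)=S)c2cc(Cl)ccc21`: 78300 nM
- Compound 2 `CCN(CC)CN1C(=O)/C(=N/NC(=S)Nc2ccc(OC)cc2)c2ccccc21`: 9200 nM
- Compound 3 `CCN(CC)CN1C(=O)/C(=N/NC(=S)Nc2ccccc2)c2ccccc21`: 1600 nM

In an ADME assay on MDCK cells (Canis lupus familiaris) for cytotoxicity (a lower number here means that less compound is tolerated, a higher number that more compound is tolerated), compound 3 stands lowest of the three at 1600 nM. Compound 4 `CCN(CC)CN1C(=O)/C(=N/NC(N)=S)c2ccccc21` differs from it thus: hydrogen in place of phenyl on an amide-type nitrogen, which is hydrogen in place of phenyl on an amide-type nitrogen, or anilino to amino. For the measured compounds named here, the only measured single-place step is a 5.8-fold lower number from compound 2 to compound 3 (0.76 log units; beyond the scatter), a modest one on an aromatic carbon, so it bears only indirectly on this change. Going by the values given here, compound 1, which also carries amino there, reads far higher at 78300 nM, and on that value a large rise is expected, though no measured step isolates this change. The expected step is a 25-fold higher number from compound 3 to compound 4 (1.40 log units; beyond the scatter). For compound 4 the estimate is 40000 nM, with an expected range of 12000 nM to 120000 nM.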

Compound 4, half-maximal cytotoxic concentration: 85800 nM
Compound 4: the middle estimate sits 2.1-fold (0.33 log units) below what was measured; low and high end bracket the measured number.
By their numbers in this assay, from the lowest: compound 3; then compound 2; then compounds 1 and 4 (each within the scatter of the next).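

In this assay, anilino to amino is the largest step seen at this position: hydrogen in place of phenyl on the amide-type nitrogen gives a large rise (a 54-fold higher number from compound 3 to compound 4 (1.73 log units; beyond the scatter)), and hydrogen in place of 4-methoxyphenyl a smaller one (a 9.3-fold higher number from compound 2 to compound 4 (0.97 log units; beyond the scatter)). Chloro on an aromatic carbon, by contrast, leaves the number within the scatter (a 1.1-fold higher number from compound 1 to compound 4 (0.04 log units; within the scatter)). Nothing available explains these steps. The compounds shown leave open how a methyl or a longer alkyl chain on this nitrogen would read, and whether such a group would stay closer to amino or to anilino.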